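The source may hold more compounds than are shown below. What is called first, only, known or untested is meant among the compounds shown, and "the series" means these compounds.

For the measured compounds named here, in a functional assay on KM12 cells (Homo sapiens) for inhibition, read by sulforhodamine B assay, with a stated time of 48 h (a lower number here means a stronger inhibitor of growth, a higher number a weaker inhibitor of growth), compound 3, with structure `Nc1cc(N)c2nc(-c3ccccc3)c(Oc3ccc(F)cc3)nc2c1`, gives 40700 nM, and this is the only definite number among the three measured compounds. Compound 1, with structure `COc1ccc(Sc2nc3cc(N)cc(N)c3nc2-c2ccccc2)cc1`, gives only a limit of the assay, < 100000 nM. Compound 2, with structure `Nc1cc(N)c2nc(-c3ccccc3)c(Sc3ccc(Cl)c(Cl)c3)nc2c1`, likewise gives only a limit of the assay, < 100000 nM. Both limits are the same one, (the limit of < 100000 nM in this assay, at which 2 of the 3 values shown sit), so the size of the step that the limit leaves unreadable from compound 1 to compound 3 cannot be read, nor can the step that the limit leaves unreadable from compound 2 to compound 3 or the step that the two limits leave unreadable from compound 1 to compound 2.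

Compound 4, with structure `Nc1cc(N)c2nc(-c3ccccc3)c(Sc3ccc(F)cc3)nc2c1`, differs from compound 3 by (4-fluorophenyl)sulfanyl in place of 4-fluorophenoxy on an aromatic carbon. Going by the values given here, the two measured compounds that carry a sulfur-linked aryl group, compound 1 and compound 2, both sit at the limit, so no measured step gives a readable size for exchanging 4-fluorophenoxy for (4-fluorophenyl)sulfanyl. With nothing readable to lean on, the expectation for compound 4 is a step of a 1.0-fold lower number from compound 3 to compound 4 (0.01 log units; within the scatter), with a wide uncertainty. Compound 4 is therefore estimated at 40000 nM, within a range from 10000 nM to 100000 nM.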

Compound 4, concentration for total growth inhibition: 49000 nM
Compound 4: the middle estimate sits 1.2-fold (0.09 log units) below what was measured, within the range that was stated.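

For the compounds shown here, compound 4 supplies the first readable step in this set: a 1.2-fold higher number from compound 3 to compound 4 (0.08 log units; within the scatter). With the 4-fluorophenyl ring held constant, this assay therefore does not separate an oxygen link from a sulfur link at this aromatic carbon next to the ring nitrogen, so this one exchange leaves growth inhibition effectively unchanged. The steps from compound 1 and compound 2 to compound 4 cannot be read, because one side of each step is a limit of the assay, not a number: the limit of < 100000 nM in this assay, at which 2 of the 4 values shown sit.

As far as these compounds go, what the ring substituents on the sulfur-linked aryl group contribute therefore stays open, including whether fluoro differs from methoxy or from the two chlorines of 3,4-dichlorophenyl. Also open, from the compounds shown here alone, is whether an amine link or a methylene link at this carbon would fit the same picture as oxygen and sulfur.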